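The source may report more compounds than this note shows. Statements on the series, on what has been measured and on what is new or still open speak of the compounds shown alone.

Measured so far:
Compound 1 `CCN(c1ccc(C#N)c(Cl)c1)c1cc(-c2c[nH]nc2C)ccc1C` gives in a functional assay on CWR22R cells (Homo sapiens) for antiproliferative activity, read by CCK-8 assay, with a stated time of 6 days (a lower number here means a stronger inhibitor, a higher number a weaker inhibitor), 5380 nM.
Compound 2 `CCN(c1ccc(C#N)c(Cl)c1)c1cc(-n2ccnc2)ccc1C` gives in this assay only a limit, > 30000 nM.
Compound 3 `CCN(c1ccc(C#N)c(Cl)c1)c1cc(-c2cn[nH]c2)ccc1C` gives in this assay only a limit, > 30000 nM.

Two of the three values sit at the limit of > 30000 nM in this assay, at which 2 of the 3 values shown sit. The step of an at least 5.5-fold higher number from compound 1 to compound 2 (0.74 log units; beyond the scatter) goes with 1H-imidazol-1-yl in place of 3-methyl-1H-pyrazol-4-yl on an aromatic carbon. The step of an at least 5.5-fold higher number from compound 1 to compound 3 (0.74 log units; beyond the scatter) goes with hydrogen in place of methyl on an aromatic carbon. Between compound 2 and compound 3 the step is a step that the two limits leave unreadable from compound 2 to compound 3; the pair differs by 1H-pyrazol-4-yl in place of 1H-imidazol-1-yl on an aromatic carbon.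

Compound 4 `CCN(c1cccc(-n2ccnc2)c1)c1ccc(C#N)c(Cl)c1` is not yet measured. It differs from compound 2 by hydrogen in place of methyl on an aromatic carbon. This is the same kind of change as hydrogen in place of methyl on an aromatic carbon, not the same: there the place is on a five-membered aromatic ring with 2 nitrogen, here on a six-membered aromatic ring of carbon only, para to a 1H-imidazol-1-yl group. The earlier step of this kind, an at least 5.5-fold higher number from compound 1 to compound 3 (0.74 log units; beyond the scatter), weakened. From compound 2 to compound 4 a step that the limit leaves unreadable from compound 2 to compound 4 is expected in this assay, resting on that earlier step and on compound 2 already sitting at a limit. Compound 4 is expected at 40000 nM, most likely again reported only as a limit.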

Compound 4, half-maximal inhibitory concentration: > 30000 nM
Compound 4 gave a limit, no number (the forecaster's own chance of this, stated with the estimate: 85%); the middle value is on the limit's open side.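

Compound 2 and compound 4 both give only a limit, not a number, so no step can be read between them: the limit of > 30000 nM in this assay, at which 3 of the 4 values shown sit. Still open, from the compounds shown here alone, is what hydrogen in place of methyl on the six-membered aromatic ring does to activity when the 1H-imidazol-1-yl group is present.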